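Benzoate in place of carbamate on a triazole scaffold

The compounds below may be only part of what the source reports. "The series", "measured", "known", "first", "only" and "open" are said of these compounds alone.

Of the compounds shown here, three have been tested in an assay on nucleic acid for inhibition of Nucleic Acid, read by fluorescence, tested at 100 uM; on this read-out higher numbers stand for more inhibition at the one concentration tested (going by the name of the read-out) and lower numbers for less inhibition. Compound 1 `CCCCN(CCCC)Cc1cn(CC(O)COC(=O)NCc2ccccc2)nn1` gives 42%, compound 2 `CN(Cc1cn(CC(O)COC(=O)c2ccccc2)nn1)CC1CCCCC1` gives 6%, and compound 3 `CCCCNC(=O)OCC(O)Cn1cc(CN(C)CCC(C)C)nn1` gives 24%. Compound 3 thus stands second of the three: compound 1 sits higher by a margin beyond the usual scatter, and compound 2 sits lower by a margin of the same size, also beyond the scatter.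

Compound 4 `CC(C)CCN(C)Cc1cn(CC(O)COC(=O)c2ccccc2)nn1` has not yet been measured. It differs from compound 3 in one place: phenyl in place of butylamino on a carbonyl carbon. Compound 4 therefore carries the same benzoyl group found in compound 2, which gave the lowest number of the set in this assay, while the carbamate of compound 3 resembles that of compound 1, the highest. Among the measured compounds shown here, no step between two measured compounds isolates this change, so the expectation rests on that resemblance alone.

For compound 4, a downward step of a number 12 percentage points lower from compound 3 to compound 4 (beyond the scatter) is expected in this assay, modest and close to the edge of the scatter. The estimated value for compound 4 is 12%, with a likely range from 2% to 28%.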

Compound 4, a percentage reported as inhibition, at one concentration (the size of the read-out at that concentration, not a potency): 0%
Beside the measured number, compound 4's estimate is 12 percentage points above it, outside the stated range (below it).
By their numbers in this assay, from the lowest: compounds 4 and 2 (each within the scatter of the next); then compound 3; then compound 1.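

In this assay, phenyl in place of butylamino on a carbonyl carbon gives a number 24 percentage points lower from compound 3 to compound 4 (beyond the scatter) with the rest of the molecule unchanged, the first direct test of this position. With the benzoyl group kept, isobutyl in place of cyclohexyl gives a number 6 percentage points lower from compound 2 to compound 4 (within the scatter) so that swap on the amine side cannot be told apart from ordinary scatter in this pair. Nothing measured here explains why the butylcarbamoyl to benzoyl change lowers the number.

Compound 1 also carries a carbamate but differs from compound 3 in more than one place, so the separate contributions of its benzylamino and dibutylamino groups remain unresolved. On these data alone, how an ethylamino group or a pyridine ring on the same carbonyl carbon would read also remains open.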